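A few compounds are considered here, and "the series" means these few. Any claim that something is new, unique, unknown or untested is made for them only; others in the source may bear on it.

Compound 1 `CC1(C)C=C(n2ccccc2=O)c2cc(S(=O)(=O)N=[N+]=[N-])ccc2O1`: 88.3%
Compound 2 `CC1(C)C=C(n2ccccc2=O)c2cc(S(=O)(=O)NCc3ccccc3)ccc2O1`: 71.1%

Of the compounds shown here, two sharing the same core have been measured in a functional assay on the whole organism (aorta) with Rattus norvegicus as the target; on this read-out lower numbers stand for smaller maximal responses and higher numbers for larger maximal responses. For the measured compounds named here, compound 2 gives 71.1%, the lower of the two numbers, and the only step known so far, a number 17.2 percentage points lower from compound 1 to compound 2 (beyond the scatter), lies beyond the scatter and is modest in size. Compound 3 `CC1(C)C=C(n2ccccc2=O)c2cc(S(=O)(=O)Nc3ccc(C#N)cc3)ccc2O1` differs from compound 2 in one place: 4-cyanophenyl in place of benzyl on a sulfonamide nitrogen. Going by the values given here, no measured step changes the group on the sulfonamide nitrogen itself; the single known step concerns the group on the sulfonyl sulfur, so it bears only indirectly on this change. With so little to go on, the estimate for compound 3 stays close to compound 2, and the expected step of a number 0.9 percentage points higher from compound 2 to compound 3 (within the scatter) is within the scatter, in no settled direction. Compound 3 is therefore expected to give about 72%, between 50% and 92%.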

Compound 3, largest response reached (Emax), in percent of the reference or control that the assay uses: 84%
Compound 3: middle estimate off by 12 percentage points, on the low side; the range from low to high includes it.
By their numbers in this assay, from the lowest: compound 2; then compounds 3 and 1 (each within the scatter of the next).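

In this assay, the group on the sulfonamide nitrogen proves able to shift the maximal response: a number 12.9 percentage points higher from compound 2 to compound 3 (beyond the scatter), the first step seen at this nitrogen. The lower number of the benzylamino compound is therefore not shared by both sulfonamides, since a number 4.3 percentage points lower from compound 1 to compound 3 (within the scatter), which leaves the (4-cyanophenyl)amino and azido compounds indistinguishable here. Nothing available explains this shift.

The step from benzyl to 4-cyanophenyl changes two things at once, the carbon link to the ring and the nitrile, so the compounds shown cannot say which one accounts for it. A plain phenyl on the sulfonamide nitrogen would separate the two, and a 4-cyanobenzyl group would test the same question from the other side.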